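The source may hold more compounds than are shown below. What is called first, only, known or untested is meant among the compounds shown, and "the series" means these compounds.

Compound 1 `O=S(=O)(Nc1ccc(F)c(C#Cc2ccc3[nH]ncc3c2)c1F)c1cccnc1`: in a functional assay on HCT-116 cells (Homo sapiens) for antiproliferative activity, read by MTT assay, with a stated time of 68 h (a higher number here means a weaker inhibitor, a lower number a stronger inhibitor), compound 1 gives > 10000 nM, a limit of the assay rather than a number.
Compound 2 `COc1n[nH]c2ncc(C#Cc3c(F)ccc(NS(=O)(=O)c4cccnc4)c3F)cc12`: in this assay compound 2 gives 1280 nM.
Compound 3 `O=S(=O)(Nc1ccc(F)c(C#Cc2cnc3[nH]nc(C4CC4)c3c2)c1F)c1cccnc1`: in this assay compound 3 gives 584 nM.

Of the two numbers measured, compound 3 has the lowest; its nearest neighbour is compound 2, and the step of a 2.2-fold lower number from compound 2 to compound 3 (0.34 log units; beyond the scatter) lies beyond the scatter, though it is modest. For compound 1 only the limit of > 10000 nM in this assay, at which 1 of the 3 values shown sits, is known, so it cannot be placed against the others.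

Compound 4 `O=S(=O)(Nc1ccc(F)c(C#Cc2cnc3[nH]nc(-c4ccc(F)cc4)c3c2)c1F)c1cccnc1` differs from compound 3 in one place: 4-fluorophenyl in place of cyclopropyl on an aromatic carbon. Among the measured compounds shown here, the only measured step at this position is the one from methoxy to cyclopropyl, a 2.2-fold lower number from compound 2 to compound 3 (0.34 log units; beyond the scatter), which shows that this part of the core tolerates a small carbon group and that a change here moves the number only modestly. For the measured compounds named here, no measured compound carries an aromatic ring at this spot, so the effect of the larger 4-fluorophenyl has no direct precedent in these data. The expectation is therefore a step from compound 3 to compound 4 of about the size of the known step or smaller, in either direction, most likely within the scatter: a 1.3-fold lower number from compound 3 to compound 4 (0.11 log units; within the scatter). For compound 4 the estimated value in this assay is 450 nM, with a range from 120 nM to 2500 nM.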

Compound 4, half-maximal inhibitory concentration: > 10000 nM
Compound 4: no number, only a limit; the forecaster's own chance of this, stated with the estimate: 10%; at least 22-fold (1.34 log units) between middle value and limit.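

Placing 4-fluorophenyl on this aromatic carbon of the five-membered ring gives an at least 17-fold higher number from compound 3 to compound 4 (1.23 log units; beyond the scatter), and against the methoxy group it gives an at least 7.8-fold higher number from compound 2 to compound 4 (0.89 log units; beyond the scatter), both in this assay. The earlier compounds shown here showed only a modest shift between methoxy and cyclopropyl, whereas this change shows that the position does not accept every group: a six-membered aromatic ring of 7 heavy atoms, replacing a three-membered ring of 3, comes with a large rise in the number. Compound 4 gives a limit of the assay rather than a number, so the true size of both steps remains unknown: the limit of > 10000 nM in this assay, at which 2 of the 4 values shown sit.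

The compounds shown do not tell whether the rise follows the aromatic ring itself, its fluorine or simply the larger number of heavy atoms. A plain phenyl, a saturated cyclohexyl ring or a short chain such as ethyl at this carbon would help separate these possibilities, and an amine there would test a group of a different kind.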